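This account rests on a few compounds, and the source may have more. Where it says the series, first, only, none or still open, it means among the compounds named here.

Compound 1 `COc1cc2oc(-c3cccc(NC(=O)c4ccccc4Br)c3)cc(=O)c2c(OC)c1OC` is the weakest of the three measured compounds in a functional assay on HepG2 cells (Homo sapiens) for inhibition, read by MTT assay (on this read-out higher numbers stand for weaker inhibition of growth and lower numbers for stronger inhibition of growth), where compound 1 gives 23100 nM. Compound 2 `COc1cc2oc(-c3cccc(NC(=O)c4ccc([N+](=O)[O-])cc4)c3)cc(=O)c2c(OC)c1OC` gives 18800 nM in this assay, a change that is a 1.2-fold lower number from compound 1 to compound 2 (0.09 log units; within the scatter) and so within the scatter. Compound 3 `COc1cc2oc(-c3cccc(NC(=O)c4ccc(C#N)cc4)c3)cc(=O)c2c(OC)c1OC` gives 10200 nM in this assay, a step of a 2.3-fold lower number from compound 1 to compound 3 (0.36 log units; beyond the scatter). Between the two, the step of a 1.8-fold lower number from compound 2 to compound 3 (0.27 log units; within the scatter) stays within the scatter.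

Compound 4 `COc1ccc(C(=O)Nc2cccc(-c3cc(=O)c4c(OC)c(OC)c(OC)cc4o3)c2)cc1` carries a further exchange of the aryl group on the carbonyl carbon: 4-methoxyphenyl in place of 2-bromophenyl on a carbonyl carbon. The two steps that bear on it, the step of a 1.2-fold lower number from compound 1 to compound 2 (0.09 log units; within the scatter) and the step of a 2.3-fold lower number from compound 1 to compound 3 (0.36 log units; beyond the scatter), both point toward lower numbers, one within and one just beyond the scatter. The expected step is therefore a 1.5-fold lower number from compound 1 to compound 4 (0.19 log units; within the scatter), modest and likely within the scatter. Compound 4 is estimated at 15000 nM in this assay, in a range from 7000 nM to 35000 nM.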

Compound 4, concentration for 50% growth inhibition: 22200 nM
Compound 4: middle estimate off by 1.5-fold (0.17 log units), on the low side; the measured number falls inside the stated range.
By their numbers in this assay, from the lowest: compounds 3, 2, 4 and 1 (each within the scatter of the next, the first and the last beyond it).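

In this assay, 4-methoxyphenyl on the carbonyl carbon cannot be told apart from 2-bromophenyl, a 1.0-fold lower number from compound 1 to compound 4 (0.02 log units; within the scatter), or from 4-nitrophenyl, a 1.2-fold higher number from compound 2 to compound 4 (0.07 log units; within the scatter), so neither exchange at this position separates its pair. Only methoxy in place of cyano on an aromatic carbon goes beyond the scatter, a 2.2-fold higher number from compound 3 to compound 4 (0.34 log units; beyond the scatter), which sets compound 3 apart from both compound 1 and compound 4, though not from compound 2. No evidence is at hand that would explain this difference.

From the compounds shown here alone, how an amine or a carboxylic acid in place of the cyano would read remains open. So does whether 2-cyanophenyl would read like 4-cyanophenyl on the same carbonyl carbon.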